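Swapping methyl for nitro on the amide-bearing phenyl

The source may hold more compounds than are shown below. What is called first, only, known or untested is meant among the compounds shown, and "the series" means these compounds.

Measured so far:
compound 1 `CC(=O)Oc1ccc(/C=C/S(=O)(=O)CCc2ccc(NC(=O)c3ccccc3)cc2)cc1OC(C)=O` — 108000 nM
compound 2 `CC(=O)Oc1ccc(/C=C/S(=O)(=O)CCc2ccc(NC(=O)c3ccc(C)cc3)cc2)cc1OC(C)=O` — 177000 nM

The two measured compounds share one core and differ only in the substituent on the phenyl of the benzamide. In an ADME assay on TZM cells (Homo sapiens) for cytotoxicity, read by CCK-8 assay, with a stated time of 2 days (a lower number here means that less compound is tolerated, a higher number that more compound is tolerated), compound 1 gives 108000 nM, and compound 2 gives 177000 nM. Within the data shown here, the single measured step is a 1.6-fold higher number from compound 1 to compound 2 (0.21 log units; within the scatter). On the numbers shown compound 2 holds the highest of the two values, but its gap to compound 1 lies within the scatter, so no order between them can be claimed.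

Compound 3 `CC(=O)Oc1ccc(/C=C/S(=O)(=O)CCc2ccc(NC(=O)c3ccc([N+](=O)[O-])cc3)cc2)cc1OC(C)=O` is the next member. Its change from compound 2 is nitro in place of methyl on an aromatic carbon. Among the measured compounds shown here, the only step that bears on it, a 1.6-fold higher number from compound 1 to compound 2 (0.21 log units; within the scatter), concerns the same aromatic carbon but exchanges hydrogen and methyl rather than methyl and nitro, and it stayed within the scatter; nothing measured here speaks directly to a nitro group. On that basis the expected step in this assay is small, a 1.2-fold lower number from compound 2 to compound 3 (0.07 log units; within the scatter), with no clear direction. Compound 3 is therefore estimated at 150000 nM, with a range from 70000 nM to 320000 nM.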

Compound 3, half-maximal cytotoxic concentration: 160000 nM
The estimate for compound 3 lay 1.1-fold (0.03 log units) below the measured number, within the range that was stated.
By their numbers in this assay, from the lowest: compounds 1, 3 and 2 (each within the scatter of the next).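

In this assay, nitro in place of methyl on this aromatic carbon, para to a large group, gives a 1.1-fold lower number from compound 2 to compound 3 (0.04 log units; within the scatter), and nitro in place of hydrogen gives a 1.5-fold higher number from compound 1 to compound 3 (0.17 log units; within the scatter). Together with a 1.6-fold higher number from compound 1 to compound 2 (0.21 log units; within the scatter), these steps show that all three groups at this position, hydrogen, methyl and nitro, lie within the scatter of one another, even though the entering nitro brings three heavy atoms and two hydrogen-bond acceptors where methyl has one heavy atom and none. No accompanying evidence bears on this result.

The compounds shown leave open whether an amine, a carboxylic acid or a longer chain on the same aromatic carbon would also stay within the scatter of these three. They also leave open whether hydrogen, methyl and nitro would remain indistinguishable in this read-out on a core other than the one shared here.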